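Replacing the pyrazolyl group in a cytotoxicity series

The source may report more compounds than this note shows. Statements on the series, on what has been measured and on what is new or still open speak of the compounds shown alone.

Measured so far:
compound 1, `Cc1nn(C)c(Oc2ccc(Cl)cc2)c1/C=N/OCc1ccc(C(=O)OC(C)(C)C)cc1`: 0.1 ug/mL in a functional assay on A549 cells (Homo sapiens) for cytotoxicity; a higher number here means a weaker inhibitor, a lower number a stronger inhibitor
compound 2, `Cc1nn(C)c(-n2cccn2)c1/C=N/OCc1ccc(C(=O)OC(C)(C)C)cc1`: 2.49 ug/mL in this assay

Among the compounds with values here, compound 2 holds the highest of the two numbers in this assay, and compound 1 is its only neighbour. Within the data shown here, the single measured step, a 25-fold higher number from compound 1 to compound 2 (1.40 log units; beyond the scatter), shows that exchanging the group on this aromatic carbon of the shared core moves the number a long way.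

Compound 3, `Cc1nn(C)c(N(C)C)c1/C=N/OCc1ccc(C(=O)OC(C)(C)C)cc1`, is not yet measured. It differs from compound 2 by dimethylamino in place of 1H-pyrazol-1-yl on an aromatic carbon. Among the measured compounds shown here, no measured step compares a ring-free group with a pyrazolyl group at this position, so the direction of the change cannot be read from the data; only the size of a 25-fold higher number from compound 1 to compound 2 (1.40 log units; beyond the scatter) suggests that this position is sensitive. Compound 3 is therefore expected to sit near compound 2 with a modest shift, a 1.6-fold higher number from compound 2 to compound 3 (0.21 log units; within the scatter). In this assay compound 3 is expected to give about 4 ug/mL, within 1 ug/mL to 16 ug/mL.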

Compound 3, half-maximal inhibitory concentration: 2.76 ug/mL
Beside the measured number, compound 3's estimate is 1.4-fold (0.16 log units) above it, and the stated range covers the measured number.
By their numbers in this assay, from the lowest: compound 1; then compounds 2 and 3 (each within the scatter of the next).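

In this assay, the ring-free dimethylamino group and the aromatic 1H-pyrazol-1-yl group cannot be told apart on this aromatic carbon: a 1.1-fold higher number from compound 2 to compound 3 (0.04 log units; within the scatter), despite the difference between them in ring and heavy atoms. The other new step, a 28-fold higher number from compound 1 to compound 3 (1.44 log units; beyond the scatter), shows that leaving 4-chlorophenoxy for a second, quite different group also moves the number a long way, so among the three groups shown only 4-chlorophenoxy stands apart. Nothing at hand explains these numbers.

Going by these compounds, whether a plain phenoxy group or a methoxy group on this carbon would keep the low number of compound 1 remains open. On these data alone, it is equally open whether a larger amine, such as piperidine, would stay with compound 2 and compound 3.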